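Removing the aryl group from the amidine of compound 2

This account rests on a few compounds, and the source may have more. Where it says the series, first, only, none or still open, it means among the compounds named here.

Measured compounds and their values in a functional assay on DU-145 cells (Homo sapiens) for cytotoxicity, read by MTT assay, with a stated time of 48 h; a higher number here means a weaker inhibitor, a lower number a stronger inhibitor:
compound 1 `COc1ccc(N/C(CCNC2=CC(=O)c3ccccc3C2=O)=N\S(=O)(=O)c2ccc(C)cc2)cc1` gives 12000 nM
compound 2 `Cc1ccc(S(=O)(=O)/N=C(/CCNC2=CC(=O)c3ccccc3C2=O)Nc2ccc(F)cc2)cc1` gives 12200 nM
compound 3 `Cc1ccc(S(=O)(=O)/N=C(/CCNC2=CC(=O)c3ccccc3C2=O)NC2CCCCC2)cc1` gives 16600 nM

Compound 2 stands second highest of the three numbers, yet all three lie close together: one neighbouring step is a 1.0-fold higher number from compound 1 to compound 2 (0.01 log units; within the scatter) and the other is a 1.4-fold higher number from compound 2 to compound 3 (0.13 log units; within the scatter), both within the scatter. Compound 4 `Cc1ccc(S(=O)(=O)/N=C(\N)CCNC2=CC(=O)c3ccccc3C2=O)cc1` has not been measured in this assay. It differs from compound 2 by hydrogen in place of 4-fluorophenyl on an amine nitrogen.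

Going by the values given here, no measured step removes the substituent on this nitrogen altogether. The nearest comparisons swap one substituent for another: a 1.4-fold higher number from compound 1 to compound 3 (0.14 log units; within the scatter) and a 1.4-fold higher number from compound 2 to compound 3 (0.13 log units; within the scatter), both within the scatter, and a 1.0-fold higher number from compound 1 to compound 2 (0.01 log units; within the scatter), also within the scatter. Nothing measured here therefore points to a large shift, while the more drastic change to hydrogen leaves room for a weaker result. The expected step from compound 2 is a 1.5-fold higher number from compound 2 to compound 4 (0.17 log units; within the scatter), leaning towards a slightly higher number. Compound 4 is estimated at 18000 nM, with a range from 8000 nM to 50000 nM.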

Compound 4, half-maximal inhibitory concentration: 30900 nM
Beside the measured number, compound 4's estimate is 1.7-fold (0.23 log units) below it; the measured number falls inside the stated range.
By their numbers in this assay, from the lowest: compounds 1, 2, 3 and 4 (each within the scatter of the next, the first and the last beyond it).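

In this assay the amine nitrogen proved sensitive only once its substituent was removed altogether: the earlier swaps among 4-methoxyphenyl, 4-fluorophenyl and cyclohexyl all stayed within the scatter. Hydrogen in place of an aromatic ring gives a 2.5-fold higher number from compound 2 to compound 4 (0.40 log units; beyond the scatter) and a 2.6-fold higher number from compound 1 to compound 4 (0.41 log units; beyond the scatter) as modest steps beyond the scatter. Hydrogen in place of cyclohexyl gives a 1.9-fold higher number from compound 3 to compound 4 (0.27 log units; within the scatter) within the scatter, so compound 3 and compound 4 cannot be told apart, and the separation holds only against the two aryl compounds.

Nothing available explains this shift. Going by these compounds, it also remains open whether a small group such as methyl on this nitrogen, or a benzyl group, would keep the number near those of compound 1 and compound 2 or fall nearer that of compound 4.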